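A Second Chlorine on the Phenyl Ring of Compound 2

The compounds below may be only part of what the source reports. "The series", "measured", "known", "first", "only" and "open" are said of these compounds alone.

Of the compounds shown here, two from this series have been tested in a functional assay on MCF7 cells (Homo sapiens) for antiproliferative activity, read by MTT assay, with a stated time of 48 h; on this read-out higher numbers stand for weaker inhibition and lower numbers for stronger inhibition. Compound 1 `COc1ccc(-n2nncc2CN2C(=O)C3(C(C#N)=C(N)Oc4c3c3nc5ccccc5nc3c3ccccc43)c3ccccc32)cc1` returned only the limit of the assay, > 50000 nM, and not a number. Compound 2 `N#CC1=C(N)Oc2c(N)cc3nc4ccccc4nc3c2C12C(=O)N(Cc1cnnn1-c1ccccc1Cl)c1ccccc12` gives 34400 nM in this assay, the only number shown. The other value shown belongs to compound 1 and is a limit, (the limit of > 50000 nM in this assay, at which 1 of the 2 values shown sits). Compound 3 `N#CC1=C(N)Oc2c(N)cc3nc4ccccc4nc3c2C12C(=O)N(Cc1cnnn1-c1cc(Cl)ccc1Cl)c1ccccc12` has not been measured. It differs from compound 2 in one place: chloro in place of hydrogen on an aromatic carbon. Put one bond further out, the 2-chlorophenyl of compound 2 becomes a 2,5-dichlorophenyl in compound 3. Going by the values given here, no measured pair shows the effect of this kind of change, so the step in this assay is expected to be small, with no direction clear beyond the scatter. The estimated change from compound 2 to compound 3 is a 1.1-fold lower number from compound 2 to compound 3 (0.06 log units; within the scatter). Compound 3 is therefore expected to give about 30000 nM, within a range from 12000 nM to 70000 nM.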

Compound 3, half-maximal inhibitory concentration: 33200 nM
Estimate against measurement, compound 3: 1.1-fold (0.04 log units) below; the measured number falls inside the stated range.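

Going by these compounds alone, compounds 2 and 3 form the first pair here that differs in one place and has a number at both ends, so the effect of a single change can be read directly. In this assay, placing a chloro group on the phenyl ring, para to the chloro group already there and meta to a large group, gives a 1.0-fold lower number from compound 2 to compound 3 (0.02 log units; within the scatter), so this assay does not tell the two compounds apart. Compound 1 cannot be set against either of them, as it differs in more than one place and gives a limit, not a number: the limit of > 50000 nM in this assay, at which 1 of the 3 values shown sits.

Still open, on these data alone, is whether a carboxylic acid or a dimethylamino group at this position would read differently from chloro. A single step also cannot show whether chloro behaves the same way elsewhere on this phenyl ring.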